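The source may hold more compounds than are shown below. What is called first, only, known or untested is meant among the compounds shown, and "the series" means these compounds.

Measured compounds:

Compound 1, `O=C(O)CCCc1ccc(NCc2cccc(Oc3ccccc3)c2)cc1`, gives 59%.
Compound 2, `Cc1nc(-c2ccc(C(F)(F)F)cc2)sc1CNc1ccc(CCCC(=O)O)cc1`, gives 44%.
Compound 3, `O=C(O)/C=C/c1ccc(NCc2cccc(Oc3ccccc3)c2)cc1`, gives 76%.

All three were tested in a functional assay on CHO cells for agonist activity at Free fatty acid receptor 1 (Homo sapiens), read by a luciferase reporter; a lower number here means a smaller maximal response, a higher number a larger maximal response. Compound 1 and compound 3 share one core, and compound 2 is built on a different core; how the two cores differ is not broken down here. Within the first core, compound 3 differs from compound 1 by one change: 2-carboxyethenyl in place of 3-carboxypropyl on an aromatic carbon. That change made a step of a number 17 percentage points higher from compound 1 to compound 3 (beyond the scatter). Compound 2 stands lowest of the three measured values, and its gap to each of the other two is beyond the usual scatter.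

Compound 4, `Cc1nc(-c2ccc(C(F)(F)F)cc2)sc1CNc1ccc(/C=C/C(=O)O)cc1`, has not been measured. It is the same change applied to the core of compound 2: 2-carboxyethenyl in place of 3-carboxypropyl on an aromatic carbon. For the measured compounds named here, the change is the same as the one from compound 1 to compound 3, down to where it sits, so the one measured step is the only guide. If the second core responds like the first, compound 4 is expected to rise by about a number 16 percentage points higher from compound 2 to compound 4 (beyond the scatter) in this assay, resting on the step of a number 17 percentage points higher from compound 1 to compound 3 (beyond the scatter) and on compound 2 at 44%. The cores differ, so the transfer is uncertain. A single earlier step is a thin base. Compound 4 is therefore estimated at 60%, with a plausible range from 47% to 74%.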

Compound 4, largest response reached (reported as percent of maximum), in percent of the reference or control that the assay uses: 95%
The estimate for compound 4 lay 35 percentage points below the measured number; measured number above the stated range.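

In this assay, putting 2-carboxyethenyl in place of 3-carboxypropyl on the core of compound 2 gave a step of a number 51 percentage points higher from compound 2 to compound 4 (beyond the scatter). The same swap, at the same place, raised the maximal response on both cores, but the size of the rise did not carry over from one core to the other: the same change on two cores in this assay, a number 17 percentage points higher (beyond the scatter) from compound 1 to compound 3 and a number 51 percentage points higher (beyond the scatter) from compound 2 to compound 4, 34 percentage points apart, beyond the scatter of two such steps. So in this small series the direction of the change transferred and its size did not, though two pairs cannot show that the direction would hold on a further core, nor which part of the core sets the size of the step.

The compounds shown leave open whether the rise comes from the double bond or from the shorter chain, a question that a 2-carboxyethyl group, the saturated form of 2-carboxyethenyl, could help to settle on both cores. They also leave open how the change affects the concentration needed for a response, since the read-out here is only the largest response reached, and a strong maximal response says nothing by itself about potency.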